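The source may hold more compounds than are shown below. What is called first, only, known or untested is meant among the compounds shown, and "the series" means these compounds.

Compound 3 `CCCC(C)n1c(CC)nc2c(-c3ccc(Cl)cc3Cl)ccnc21` carries the lowest number of the three measured in an assay for binding affinity to Corticotropin releasing factor receptor (Rattus norvegicus) (on this read-out higher numbers stand for weaker inhibition and lower numbers for stronger inhibition), where compound 3 gives 0.5 nM. Compound 2 `CCc1nc2c(-c3ccc(Cl)cc3Cl)ccnc2n1C(C)C1CCC1` gives 1 nM in this assay, and the step of a 2.0-fold lower number from compound 2 to compound 3 (0.30 log units; within the scatter) does not separate the two. Compound 1 `CCCC(C)n1c(CC)nc2c(-c3ccc(Cl)cc3C(C)=O)ccnc21` gives 95.6 nM; the step of a 190-fold lower number from compound 1 to compound 3 (2.28 log units; beyond the scatter) is the only large one in the set and concerns the same aromatic carbon that is changed in compound 4 `CCCC(C)n1c(CC)nc2c(-c3ccc(C(C)O)cc3Cl)ccnc21`, which differs from compound 3 by 1-hydroxyethyl in place of chloro on an aromatic carbon.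

The step from compound 1 to compound 3 bears directly on this change: compound 1 carries acetyl on that aromatic carbon, and exchanging it for chloro lowered the number by a 190-fold lower number from compound 1 to compound 3 (2.28 log units; beyond the scatter). Compound 4 replaces the chloro again with a three-heavy-atom group, so a return toward the number of compound 1 is expected, though not necessarily the full distance. For compound 4 the expected step is an 80-fold higher number from compound 3 to compound 4 (1.90 log units; beyond the scatter), a rise beyond the scatter. Compound 4 is therefore estimated at 40 nM in this assay, with a range from 8 nM to 200 nM.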

Compound 4, inhibition constant: 5.1 nM
Compound 4: middle estimate off by 7.8-fold (0.89 log units), on the high side; the measured number lies below the stated range.
By their numbers in this assay, from the lowest: compounds 3 and 2 (each within the scatter of the next); then compound 4; then compound 1.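

In this assay, 1-hydroxyethyl in place of chloro on the aromatic carbon meta to a chloro group and para to a large group gives a 10-fold higher number from compound 3 to compound 4 (1.01 log units; beyond the scatter), so this carbon responds to the exchange beyond the scatter. The acetyl of compound 1 stands on a different aromatic carbon, and compound 1 and compound 4 differ in more than one place, so the step from compound 1 cannot be carried over to this position and this position now has its own reading. No measurement on hand accounts for the rise at this carbon.

The compounds shown leave open whether the rise follows the hydroxyl or the carbon chain of 1-hydroxyethyl, which ethyl or hydroxymethyl on this carbon would separate. From the compounds shown here alone, how an amine or a carboxylic acid would read at this carbon also remains open.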